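Adding acetamido to the phenyl ring of compound 2

The source may report more compounds than this note shows. Statements on the series, on what has been measured and on what is new or still open speak of the compounds shown alone.

In a functional assay on QGY-7703 cells (Homo sapiens) for cytotoxicity, read by MTT assay, with a stated time of 24 h (a higher number here means a weaker inhibitor, a lower number a stronger inhibitor), compound 2 `O=C1/C(=C/c2cccnc2)CN(S(=O)(=O)c2ccccc2)C/C1=C\c1ccccc1F` gives 4800 nM. Within the data shown here, the only other compound measured so far, compound 1 `CN1C/C(=C\c2cccnc2)C(=O)/C(=C/c2ccc(F)cc2Br)C1`, gives 2610 nM. These two numbers lie within the usual scatter of repeated measurements, so they cannot be ranked against each other. The two structures also differ in more than one place, which means that this pair does not show the effect of any single change.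

Compound 3 `CC(=O)Nc1ccc(S(=O)(=O)N2C/C(=C\c3cccnc3)C(=O)/C(=C/c3ccccc3F)C2)cc1` matches compound 2 except at one spot. There, acetamido stands in place of hydrogen on an aromatic carbon, para to a large group, turning phenyl into 4-acetamidophenyl (acetamido in place of hydrogen on an aromatic carbon). Among the measured compounds shown here, no measured pair shows what such a change does in this assay, and that leaves no basis for predicting a direction. The expected result is therefore no shift beyond the scatter. The estimated change, a 1.3-fold lower number from compound 2 to compound 3 (0.10 log units; within the scatter), is expected to be small. For compound 3 the estimated value is 3800 nM, with an expected range of 1300 nM to 11000 nM.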

Compound 3, half-maximal inhibitory concentration: 9640 nM
Compound 3: the middle estimate sits 2.5-fold (0.40 log units) below what was measured; low and high end bracket the measured number.
By their numbers in this assay, from the lowest: compounds 1, 2 and 3 (each within the scatter of the next, the first and the last beyond it).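

Among these compounds, this is the first pair that differs in one place only, so it gives the first direct reading of a change on this phenyl ring. In this assay, acetamido in place of hydrogen, para to a large group, gives a 2.0-fold higher number from compound 2 to compound 3 (0.30 log units; within the scatter). The phenyl ring of compound 2 therefore takes on this group, with its 4 heavy atoms, a hydrogen-bond donor and a hydrogen-bond acceptor, without a shift that can be told apart from repeat measurements, and nothing on hand explains the reading.

On these data alone, one step at one spot sets no trend, so it remains open whether a small amine, a carboxylic acid or a longer chain such as propionamido at the same place would give a number clearly apart from those of compound 2 and compound 3. As far as these compounds go, it is equally open whether acetamido would behave the same way elsewhere on this ring, or whether this result would hold with a different group on the other aromatic ring of the shared core.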